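The compounds below may be only part of what the source reports. "The series", "measured", "known", "first", "only" and "open" are said of these compounds alone.

Compound 1 `CC(C)(C)Cc1csc(N)c1C(=O)c1ccc(Cl)c(Cl)c1`: 1%
Compound 2 `CC(C)(C)Cc1c(Br)sc(N)c1C(=O)c1cccc(Cl)c1`: 1%

In an assay on CHO cells for displacement of a labelled ligand from adenosine receptor A1 (Homo sapiens), read by scintillation counting, tested at 10 uM (a lower number here means less inhibition, a higher number more inhibition at the concentration tested (going by the name of the read-out)), compound 1 gives 1% and compound 2 gives 1%, so compound 2 stands level with compound 1 at the digits shown, the two values lying within the scatter of each other. Compound 3 `CC(C)(C)Cc1c(Br)sc(N)c1C(=O)c1ccc(Cl)c(Cl)c1` differs from compound 2 by chloro in place of hydrogen on an aromatic carbon. Going by the values given here, no pair of measured compounds separated by a single change is available to gauge this step. Since both measured compounds sit near the floor of this assay, the expected step of a number 2 percentage points higher from compound 2 to compound 3 (within the scatter) is none beyond the scatter. Compound 3 is therefore expected to give 3%, with a range of -5% to 15%.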

Compound 3, a percentage reported as inhibition, at one concentration (the size of the read-out at that concentration, not a potency): 1%
The estimate for compound 3 lay 2 percentage points above the measured number; measured number inside the range.
By their numbers in this assay, from the lowest: compounds 1, 2 and 3 (each within the scatter of the next).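

In this assay, adding chloro on the six-membered aromatic ring, ortho to a chloro group and para to a large group, gives no change at the digits printed from compound 2 to compound 3 (within the scatter), and adding bromo to the shared core gives no change at the digits printed from compound 1 to compound 3 (within the scatter). Going by these compounds alone, compound 3 thus provides the first reading of each single change, and near the floor of this assay neither change registers. No independent measurement bears on this result.

Open, from the compounds shown here alone, is whether an amine or a carboxylic acid at this place on the ring would lift the number off the floor. Also open, going by these compounds, is whether either halogen matters in a compound with measurable inhibition.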